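Replacing oxan-4-yl in compound 2

The source may hold more compounds than are shown below. What is called first, only, known or untested is meant among the compounds shown, and "the series" means these compounds.

Among the compounds with values here, in an ADME assay on microsomes from liver (Homo sapiens) for metabolic stability, with a stated time of 10 min (a lower number here means that less of the compound is left, a higher number that more of the compound is left), compound 2 `Cc1c(Cl)cccc1Oc1cccn2c(C3CCOCC3)nnc12` gives 100%, the highest number so far. Compound 3 `Cc1c(Cl)cccc1Oc1cccn2c(C3CCCCCC3O)nnc12` gives 81%. Compound 1 `COC1(c2nnc3c(Oc4cccc(Cl)c4C)cccn23)CCCCCC1` gives < 1%, which is a limit of the assay. Compound 4 `Cc1c(Cl)cccc1Oc1cccn2c(C34CCC(O)(CC3)CC4)nnc12` differs from compound 2 as follows: a group of 9 heavy atoms (8 carbon, 1 oxygen; 2 six-membered non-aromatic rings of carbon only) in place of a group of 6 heavy atoms (5 carbon, 1 oxygen; one six-membered non-aromatic ring with 1 hetero atom), on an aromatic carbon. Within the data shown here, the closest precedent is the modest a number 19 percentage points lower from compound 2 to compound 3 (beyond the scatter), where 2-hydroxycycloheptyl enters in place of oxan-4-yl. The large a number at least 99 percentage points higher from compound 1 to compound 2 (beyond the scatter) and a number at least 80 percentage points higher from compound 1 to compound 3 (beyond the scatter) both start from the limit and leave the 1-methoxycycloheptyl group, which compound 4 does not carry, so they bear less on this change. A modest fall is therefore expected, as a number 20 percentage points lower from compound 2 to compound 4 (beyond the scatter). For compound 4 the estimated value is 80%, with an expected range of 55% to 100%.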

Compound 4, percent of the compound remaining: 100%
The estimate for compound 4 lay 20 percentage points below the measured number; low and high end bracket the measured number.
By their numbers in this assay, from the lowest: compound 3; then compounds 2 and 4 (each within the scatter of the next). At a limit, below all of these: compound 1.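

In this assay, on the aromatic carbon between two ring nitrogen atoms, a group of 2 six-membered non-aromatic rings of carbon only, with 1 hydrogen-bond donor, replaces oxan-4-yl with no change at the digits printed from compound 2 to compound 4 (within the scatter), so a donor at this place need not lower the number. Against 2-hydroxycycloheptyl the same group gives a number 19 percentage points higher from compound 3 to compound 4 (beyond the scatter), so the fall seen with compound 3 does not extend to every hydroxyl-bearing group here. The remaining step, a number at least 99 percentage points higher from compound 1 to compound 4 (beyond the scatter), starts from a limit: the limit of < 1% in this assay, at which 1 of the 4 values shown sits.

From the compounds shown here alone, whether an amine in place of the hydroxyl of compound 4 would hold this number stays open. Compounds 2 and 4 cannot be separated in this assay.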